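A Longer Chain on a Small Vinyl Ketone

The compounds below may be only part of what the source reports. "The series", "measured", "known", "first", "only" and "open" are said of these compounds alone.

Among the measured compounds shown here, compound 1 `CCCCCCc1ccc(C(=O)CCN(CCCC)CCCC)cc1` is the one compound here with a number to its name: in an assay on isolated protein for displacement of a labelled ligand from thyroid hormone receptor alpha (Homo sapiens), read by fluorescence polarization (a lower number here means a stronger inhibitor, a higher number a weaker inhibitor), compound 1 gives 6900 nM. Compound 2 `C=CC(=O)c1ccc(CCC)cc1` is far smaller, a vinyl ketone carrying a propyl chain. In this assay compound 2 reaches only a limit of the assay, > 100000 nM, so its true value is not known and it stands at the limit of > 100000 nM in this assay, at which 1 of the 2 values shown sits. Compound 3 `C=CC(=O)c1ccc(CCCCC)cc1` differs from compound 2 by ethyl in place of hydrogen on a saturated chain carbon, three bonds along the chain from an aromatic carbon. For the measured compounds named here, no measured pair follows the same change, so the size of this step is open. Compound 1, with its long chain and a value in this assay of 6900 nM, is the only hint that a longer chain can go with measurable binding, but compound 1 differs from compound 3 in more than the chain. Compound 3 is therefore expected to remain weak, with an estimate in this assay of 80000 nM and a range from 25000 nM to 300000 nM. The expected step is an at least 1.2-fold lower number from compound 2 to compound 3 (0.09 log units; that floor lies within the scatter), small and perhaps not beyond the scatter.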

Compound 3, half-maximal inhibitory concentration: 60900 nM
Estimate against measurement, compound 3: 1.3-fold (0.12 log units) above; the measured number falls inside the stated range.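

With a pentyl chain in place of the propyl chain, compound 3 gives a vinyl ketone of this kind its first measured value in this assay, 60900 nM. The change reads as an at least 1.6-fold lower number from compound 2 to compound 3 (0.21 log units; that floor lies within the scatter), so it is a floor and not a size, and the data do not show whether the true step goes beyond the scatter. Compound 2 has only a limit of the assay, so the size of the step cannot be told: the limit of > 100000 nM in this assay, at which 1 of the 3 values shown sits.

As far as these compounds go, it remains open whether a longer chain, such as heptyl, on the vinyl ketone would lower the number further. From the compounds shown here alone, compound 1 differs from compound 3 in more than one place, so what its hexyl chain and its dibutylamine each contribute on their own also stays unknown.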